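Difluorophenyl positional swap on the piperazine aryl group

The source may hold more compounds than are shown below. What is called first, only, known or untested is meant among the compounds shown, and "the series" means these compounds.

The series shares one core, varied only at the aryl group on an amine nitrogen in a ring. In a functional assay on CHO cells with adenosine receptor A1 (Homo sapiens) as the target, read by cAMP accumulation and immunoassay, with a stated time of 6 min, tested at 0.01 uM (a lower number here means a stronger effect, a higher number a weaker effect of the compound at the concentration tested), compound 1 `Nc1scc(CN2CCN(c3cc(Cl)cc(Cl)c3)CC2)c1C(=O)c1ccc(Cl)cc1` gives -1%, compound 2 `Nc1scc(CN2CCN(c3ccc(F)cc3F)CC2)c1C(=O)c1ccc(Cl)cc1` gives 0% and compound 3 `Nc1scc(CN2CCN(c3ccc(F)c(F)c3)CC2)c1C(=O)c1ccc(Cl)cc1` gives -3.2%. Among the measured compounds shown here, compound 3 holds the lowest of the three numbers, but the step of a number 2.2 percentage points lower from compound 1 to compound 3 (within the scatter) and the step of a number 3.2 percentage points lower from compound 2 to compound 3 (within the scatter) both lie within the scatter, as does a number 1 percentage points higher from compound 1 to compound 2 (within the scatter), so no compound can be set apart from the others on these data.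

Compound 4 `Nc1scc(CN2CCN(c3cccc(F)c3F)CC2)c1C(=O)c1ccc(Cl)cc1` differs from compound 3 by 2,3-difluorophenyl in place of 3,4-difluorophenyl on an amine nitrogen in a ring. For the measured compounds named here, the steps that bear on this are a number 3.2 percentage points lower from compound 2 to compound 3 (within the scatter), which moves one fluorine about the same ring, and a number 2.2 percentage points lower from compound 1 to compound 3 (within the scatter), which exchanges the whole pattern; neither reached beyond the scatter, and no swap of the aryl group so far has done so. A further rearrangement of the two fluorines is therefore expected to give a step of a number 2.2 percentage points higher from compound 3 to compound 4 (within the scatter), within the scatter, in this assay.

For compound 4 the estimate is -1%, with a range from -12% to 10%.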

Compound 4, a percentage reported as activity, at one concentration (the size of the read-out at that concentration, not a potency): -13%
Compound 4: the middle estimate sits 12 percentage points above what was measured; the measured number lies below the stated range.
By their numbers in this assay, from the lowest: compounds 4, 3, 1 and 2 (each within the scatter of the next, the first and the last beyond it).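

In this assay, among the compounds shown here, the aryl group on an amine nitrogen in a ring now gives steps beyond the scatter, which no pair among compound 1, compound 2 and compound 3 gave, namely a number 13 percentage points lower from compound 2 to compound 4 (beyond the scatter) and a number 12 percentage points lower from compound 1 to compound 4 (beyond the scatter) and both are modest. Arrangement of the two fluorines can therefore matter at this position, at least between 2,3-difluorophenyl and the 2,4-difluorophenyl of compound 2, although a number 9.8 percentage points lower from compound 3 to compound 4 (within the scatter) leaves 2,3-difluorophenyl and 3,4-difluorophenyl unresolved even though the two groups hold the same atoms. No supporting evidence bears on the reason for this separation.

On these data alone, the read-out comes from a single concentration and gives no potency, so it remains open whether the separation of compound 4 from compound 1 and compound 2 would hold across a concentration range. Also open, as far as these compounds go, is whether a monofluorophenyl, a methoxyphenyl or a pyridyl group at this position would extend the step, and whether the step would persist with an amide in place of the free amine on the shared core.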